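Series notes: replacing the pyrazole at the pyridine position

A few compounds are considered here, and "the series" means these few. Any claim that something is new, unique, unknown or untested is made for them only; others in the source may bear on it.

Compound 1 `CCOc1cc(NC(=O)NCc2cc(C)c(-c3cn(C)nc3C)cn2)cc(Cl)n1` is the reference of the pair; in a functional assay on HFL1 cells for antagonist activity at sphingosine 1-phosphate receptor 2 (Homo sapiens), read by ELISA, with a stated time of 24 h, in the absence of a further agent (on this read-out higher numbers stand for weaker inhibition and lower numbers for stronger inhibition), compound 1 gives 0.032 nM. Among the measured compounds shown here, compound 2 `CCOc1cc(NC(=O)NCc2cc(C)c(-c3cn(C)nc3C(F)(F)F)cn2)cc(Cl)n1` gives 22 nM in this assay, the highest of the two numbers recorded, the single step of a 690-fold higher number from compound 1 to compound 2 (2.84 log units; beyond the scatter) separating it from compound 1. Compound 3 `CCOc1cc(NC(=O)NCc2cc(C)c(N3CC(C)OC(C)C3)cn2)cc(Cl)n1` is not yet measured. It differs from compound 2 by 2,6-dimethylmorpholin-4-yl in place of 1-methyl-3-(trifluoromethyl)-1H-pyrazol-4-yl on an aromatic carbon. For the measured compounds named here, no measured step covers an exchange of this kind: the only step in hand, a 690-fold higher number from compound 1 to compound 2 (2.84 log units; beyond the scatter), concerns a substituent on the ring that now leaves entirely, and it shows that this position of the shared core responds to small changes with large shifts. That is the sole bearing on the present step; direction cannot be inferred from it. For compound 3 the expectation is therefore a broad one, a step of a 2.2-fold lower number from compound 2 to compound 3 (0.34 log units; beyond the scatter) with a wide margin, giving an estimate of 10 nM, bounded by 0.3 nM and 300 nM.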

Compound 3, half-maximal inhibitory concentration: 105 nM
The estimate for compound 3 lay 11-fold (1.02 log units) below the measured number; measured number inside the range.
By their numbers in this assay, from the lowest: compound 1; then compound 2; then compound 3.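

In this assay, the whole five-membered aromatic ring can leave for the six-membered non-aromatic 2,6-dimethylmorpholin-4-yl at a modest cost relative to the trifluoromethyl pyrazole (a 4.8-fold higher number from compound 2 to compound 3 (0.68 log units; beyond the scatter)). Among the compounds shown here, that step is much smaller than the one made by the single trifluoromethyl-for-methyl exchange on the pyrazole (a 690-fold higher number from compound 1 to compound 2 (2.84 log units; beyond the scatter)), so here the choice of substituent on the pyrazole weighs more than the presence of the pyrazole itself, provided that substituent is trifluoromethyl. Against the 1,3-dimethyl-1H-pyrazol-4-yl of compound 1, the same morpholine is far behind (a 3300-fold higher number from compound 1 to compound 3 (3.52 log units; beyond the scatter)), and nothing available accounts for any of these steps.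

Open, as far as these compounds go, is whether plain morpholin-4-yl or a dimethylamino group would sit nearer compound 3 or compound 1. Also open, from the compounds shown here alone, is whether a pyrazole bearing ethyl in place of the 3-methyl keeps the number of compound 1.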